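Extending the Amide Chain on a Shared Core

The compounds below may be only part of what the source reports. "The series", "measured", "known", "first", "only" and "open" are said of these compounds alone.

Compound 2 `CNC(=O)/C=C/[C@H]1C[C@@H](O)[C@@H](O)C1` was tested in an ADME assay on S2 cells (Drosophila melanogaster) for cytotoxicity, read by MTT assay; on this read-out higher numbers stand for an effect only at larger amounts of compound and lower numbers for an effect already at smaller amounts. There compound 2 gives only a limit, > 250000 nM. Compound 1 `CCOC(=O)/C=C/[C@H]1C[C@@H](O)[C@@H](O)C1` also gives only a limit in this assay, > 350000 nM. The step that the two limits leave unreadable from compound 1 to compound 2 cannot be read, as both values sit at limits, the limit of > 250000 nM in this assay, at which 1 of the 2 values shown sits, and (the limit of > 350000 nM in this assay, at which 1 of the 2 values shown sits). Compound 3 `CCCCNC(=O)/C=C/[C@H]1C[C@@H](O)[C@@H](O)C1` differs from compound 2 by propyl in place of hydrogen on a saturated chain carbon bound to an amide-type nitrogen. No readable step bears on this change, so the two limits leave its size unknown. Compound 3 is expected to give about 250000 nM in this assay, within 100000 nM to 600000 nM. This expectation corresponds to an estimated step of a number no higher from compound 2 to compound 3 (the limit leaves the size open).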

Compound 3, half-maximal effective concentration: > 250000 nM
Compound 3: a limit, no number; the forecaster's own chance of this, stated with the estimate: 80%; the middle value sits exactly at the limit.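

In this assay compound 1, compound 2 and compound 3 each give only a limit, so no step among these three compounds can be read. The compounds shown leave open whether replacing methylamino with butylamino changes the read-out at all.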